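Cyclopropyl in place of methyl: expected microsomal stability

A few compounds are considered here, and "the series" means these few. Any claim that something is new, unique, unknown or untested is made for them only; others in the source may bear on it.

Measured compounds:
compound 1 `CCCCc1nc(C(C)C)c(CC(=O)OC)c(=O)n1Cc1ccc(-c2ccccc2-c2noc(=O)[nH]2)cc1`, 10.5%
compound 2 `CCCCc1nc(C)c(CC(=O)OC)c(=O)n1Cc1ccc(-c2ccccc2-c2noc(=O)[nH]2)cc1`, 69.6%

Among the compounds with values here, in an ADME assay on microsomes from liver (Homo sapiens) for metabolic stability, with a stated time of 30 min (a lower number here means that less of the compound is left, a higher number that more of the compound is left), compound 2 stands highest of the two numbers measured so far; its nearest neighbour is compound 1, with 10.5%. Within the data shown here, the one measured step, a number 59.1 percentage points higher from compound 1 to compound 2 (beyond the scatter), is large and beyond the scatter.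

Compound 3 `CCCCc1nc(C2CC2)c(CC(=O)OC)c(=O)n1Cc1ccc(-c2ccccc2-c2noc(=O)[nH]2)cc1` is the unmeasured member. It differs from compound 2 by cyclopropyl in place of methyl on an aromatic carbon. The step from compound 1 to compound 2 bears on this change, as it exchanges groups at the same aromatic carbon. That step was large; cyclopropyl brings three carbons where isopropyl brought three and methyl one, so compound 3 is expected to fall between the two measured values, nearer the lower. The expected step is a number 34.6 percentage points lower from compound 2 to compound 3 (beyond the scatter). For compound 3 the estimate in this assay is 35%, ranging from 12% to 62%.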

Compound 3, percent of the compound remaining: 24.4%
Compound 3: middle estimate off by 10.6 percentage points, on the high side, within the range that was stated.
By their numbers in this assay, from the lowest: compound 1; then compound 3; then compound 2.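

In this assay, cyclopropyl also costs most of the stability that compound 2 shows at this aromatic carbon, with a number 45.2 percentage points lower from compound 2 to compound 3 (beyond the scatter), so the loss is not unique to isopropyl. Exchanging isopropyl for cyclopropyl recovers only part of it, with a number 13.9 percentage points higher from compound 1 to compound 3 (beyond the scatter), leaving methyl the best of the three groups shown at this position. No available evidence accounts for the differences among these groups.

On these data alone, whether the fall already appears with a group such as ethyl remains open, as does how trifluoromethyl or methoxy would compare with methyl here. Also open, as far as these compounds go, is whether the same order of groups would hold with the methyl ester replaced by a carboxylic acid or the butyl chain replaced by a shorter chain.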